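Masking the diol of compound 3 as a dioxolane

A few compounds are considered here, and "the series" means these few. Any claim that something is new, unique, unknown or untested is made for them only; others in the source may bear on it.

Three compounds on the shared core differ in the group carried on the aromatic nitrogen. In a functional assay on A549 cells (Homo sapiens) for cytotoxicity, read by MTT assay, with a stated time of 72 h (a lower number here means a stronger inhibitor, a higher number a weaker inhibitor), compound 1 `O=C1c2c[n+]([O-])c3ccccc3c2C(=O)c2c1c1ccccc1n2Cc1cn([C@H]2O[C@H](CO)[C@@H](O)[C@H]2O)nn1` gives 2680 nM, compound 2 `O=C1c2c[n+]([O-])c3ccccc3c2C(=O)c2c1c1ccccc1n2Cc1cn([C@@H]2C[C@H](O)[C@@H](CO)O2)nn1` gives 120 nM and compound 3 `O=C1c2c[n+]([O-])c3ccccc3c2C(=O)c2c1c1ccccc1n2Cc1cn(C[C@H](O)CO)nn1` gives 1030 nM. Compound 3 therefore holds the second highest of the three numbers, closer to compound 1 than to compound 2.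

Compound 4 `CC1(C)OCC(Cn2cc(Cn3c4c(c5ccccc53)C(=O)c3c[n+]([O-])c5ccccc5c3C4=O)nn2)O1` differs from compound 3 as follows: 2,2-dimethyl-1,3-dioxolan-4-yl in place of 1,2-dihydroxyethyl on a saturated chain carbon bound to an aromatic nitrogen. Put simply, 2,3-dihydroxypropyl becomes (2,2-dimethyl-1,3-dioxolan-4-yl)methyl.

Going by the values given here, no measured step makes this exact change. The closest is the loss of a hydroxy on a saturated ring carbon, a large step: a 22-fold lower number from compound 1 to compound 2 (1.35 log units; beyond the scatter). The two steps that swap a ring for 2,3-dihydroxypropyl are both modest and run in opposite directions, a 2.6-fold lower number from compound 1 to compound 3 (0.42 log units; beyond the scatter) and an 8.6-fold higher number from compound 2 to compound 3 (0.93 log units; beyond the scatter), so they give no direction here. Among the compounds with values here, the hydroxy groups also go in compound 4, so the single precedent a 22-fold lower number from compound 1 to compound 2 (1.35 log units; beyond the scatter) points towards a lower number, though with low confidence. The expected change is modest, a 2.1-fold lower number from compound 3 to compound 4 (0.31 log units; beyond the scatter). Compound 4 is estimated at 500 nM, with an expected range of 130 nM to 1800 nM.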

Compound 4, half-maximal inhibitory concentration: 80 nM
The estimate for compound 4 lay 6.3-fold (0.80 log units) above the measured number, and the stated range ends above it.
By their numbers in this assay, from the lowest: compounds 4 and 2 (each within the scatter of the next); then compound 3; then compound 1.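

Working notes: in this assay, 2,2-dimethyl-1,3-dioxolan-4-yl in place of 1,2-dihydroxyethyl on a saturated chain carbon bound to an aromatic nitrogen gives a 13-fold lower number from compound 3 to compound 4 (1.11 log units; beyond the scatter), so the 2 hydrogen-bond donors of the leaving group are not needed here, and a group with 0 hydrogen-bond donors and one five-membered non-aromatic ring is accepted at this position. The ring-bearing substituents also compare differently from before: the change gives a 34-fold lower number from compound 1 to compound 4 (1.53 log units; beyond the scatter), while a 1.5-fold lower number from compound 2 to compound 4 (0.18 log units; within the scatter) means that compound 2 and compound 4 cannot be told apart, so the (2,2-dimethyl-1,3-dioxolan-4-yl)methyl group matches the 4-hydroxy-5-(hydroxymethyl)oxolan-2-yl group in this read-out. No measurement on hand accounts for the size of these steps.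

Still open, from the compounds shown here alone, is whether the step belongs to the loss of the hydroxy groups or to the dimethyl-substituted ring, which a dimethyl ether of the same diol or a plain propyl chain would separate. Going by these compounds, the part played by configuration is also open, since the leaving group carries 1 defined stereocentre and the entering group is given with none.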